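The compounds below may be only part of what the source reports. "The series", "measured", "known", "first", "only" and "open" are said of these compounds alone.

Compound 1 `CCCCCCCCCCCCCC(=O)OC(COCCCCCCCCCCCC)COP(=O)(O)OP(=O)(O)OC[C@H]1OC(n2ccc(N)nc2=O)[C@@H](O)[C@@H]1O`: in a physicochemical assay for solubility, tested at 272 nM (on this read-out higher numbers stand for higher solubility and lower numbers for lower solubility), compound 1 gives > 146000000 nM, a limit of the assay.
Compound 2 `CCCCCCCCCCCCCCCC(=O)OC(COCCCCCCCCCCCC)COP(=O)(O)OP(=O)(O)OC[C@H]1OC(n2ccc(N)nc2=O)[C@@H](O)[C@@H]1O`: in this assay compound 2 gives > 131000000 nM, a limit of the assay.

Compound 2 stands at a limit, as does compound 1. Within the data shown here, the one step measured, a step that the two limits leave unreadable from compound 1 to compound 2, cannot be read because both ends sit at the limit of > 146000000 nM in this assay, at which 1 of the 2 values shown sits, and (the limit of > 131000000 nM in this assay, at which 1 of the 2 values shown sits). Compound 3 `CCCCCCCCCCCCCCCC(=O)OC(COCCCCCCCCCCCCCC)COP(=O)(O)OP(=O)(O)OC[C@H]1OC(n2ccc(N)nc2=O)[C@@H](O)[C@@H]1O` carries the change (ethyl in place of hydrogen on a saturated chain carbon, ten or more bonds along the chain from an oxygen on a saturated carbon). That is the same kind of change as the measured step, so no shift beyond the scatter is expected; compound 3 is estimated at 150000000 nM, between 50000000 nM and 400000000 nM, which means an expected step that the limit leaves unreadable from compound 2 to compound 3.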

Compound 3, solubility: > 43000000 nM
Compound 3: only a limit was reported; the forecaster's own chance of this, stated with the estimate: 80%; the middle value does not contradict the limit.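

Compound 2 and compound 3 both give only limits in this assay, so the step between them cannot be read. The compounds shown leave open where any true value lies and whether ethyl in place of hydrogen shifts the read-out at all.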